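This account rests on a few compounds, and the source may have more. Where it says the series, first, only, none or still open, it means among the compounds named here.

Of the compounds shown here, two built on a shared core have so far been measured in a functional assay (Pituitary gland cell) with Rattus norvegicus as the target; on this read-out lower numbers stand for an effect already at smaller amounts and higher numbers for an effect only at larger amounts of compound. Compound 1, `CC(C)[C@@H](O)CNC(C)(C)CC(=O)N[C@@H]1CCc2ccccc2N(Cc2ccc(-c3ccccc3-c3nn[nH]n3)cc2)C1=O`, gives 200 nM. Compound 2, `CC(C)(N)C(=O)N[C@@H]1CCc2ccccc2N(Cc2ccc(-c3ccccc3-c3nn[nH]n3)cc2)C1=O`, gives 30 nM, the lowest of the two numbers; its nearest neighbour is compound 1, and the step of a 6.7-fold lower number from compound 1 to compound 2 (0.82 log units; beyond the scatter) lies beyond the scatter. The unmeasured compound 3, `CO[C@H](C)CNC(C)(C)CC(=O)N[C@@H]1CCc2ccccc2N(Cc2ccc(-c3ccccc3-c3nn[nH]n3)cc2)C1=O`, differs from compound 2 in one place: 2-((2-methoxypropyl)amino)-2-methylpropyl in place of 1-amino-1-methylethyl on a carbonyl carbon. Within the data shown here, the single measured step that bears on this change runs the opposite way, from the larger chain of compound 1 to the small 1-amino-1-methylethyl group of compound 2, and it is a 6.7-fold lower number from compound 1 to compound 2 (0.82 log units; beyond the scatter). The chain entering compound 3 is of the same kind as that of compound 1, differing only in its 2-methoxypropyl end in place of a 2-hydroxy-3-methylbutyl end. The step is therefore expected to run back toward a higher number, by a 5.0-fold higher number from compound 2 to compound 3 (0.70 log units; beyond the scatter). Whether the methoxy chain lands exactly where compound 1 does cannot be told from two numbers. Compound 3 is estimated at 150 nM, within a range from 50 nM to 450 nM.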

Compound 3, concentration for half-maximal effect: 20 nM
Beside the measured number, compound 3's estimate is 7.5-fold (0.88 log units) above it; the whole stated range lies above it.
By their numbers in this assay, from the lowest: compounds 3 and 2 (each within the scatter of the next); then compound 1.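

In this assay, the long 2-((2-methoxypropyl)amino)-2-methylpropyl chain on the carbonyl carbon stands level with the small 1-amino-1-methylethyl group, with a 1.5-fold lower number from compound 2 to compound 3 (0.18 log units; within the scatter). Compound 1 and compound 3 both carry a long chain, and only compound 1 has the higher number. What separates the two long chains is their far end: with 1-methoxyethyl in place of 1-hydroxy-2-methylpropyl on a saturated chain carbon bound to an amine nitrogen, the result is a 10-fold lower number from compound 1 to compound 3 (1.00 log units; beyond the scatter), a clear change from an edit confined to the end of the chain. Nothing available here accounts for why this end carries so much weight.

The change from compound 1 to compound 3 alters the oxygen substituent and the rest of the chain end together, so the compounds shown do not tell which of the two accounts for the step; a 2-hydroxypropyl end or a 2-methoxy-3-methylbutyl end would pull them apart. Also open, going by these compounds, is how far the result depends on the defined stereocentre of the 2-methoxypropyl end, and whether an ethoxy group would serve in place of its methoxy group.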